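A few compounds are considered here, and "the series" means these few. Any claim that something is new, unique, unknown or untested is made for them only; others in the source may bear on it.

Of the compounds shown here, three that share one core have been tested in a functional assay on PC-3 cells (Homo sapiens) for antiproliferative activity, read by MTT assay; on this read-out lower numbers stand for stronger inhibition and higher numbers for weaker inhibition. Compound 1 `Cc1cccc(/C=N/Nc2ncc3c(n2)n(C2CCCC2)c(=O)c(=O)n3C)c1` gives 53600 nM. Compound 2 `COc1cccc(/C=N/Nc2ncc3c(n2)n(C2CCCC2)c(=O)c(=O)n3C)c1` gives 20700 nM in this assay. Compound 3 `Cn1c(=O)c(=O)n(C2CCCC2)c2nc(N/N=C/c3cccc(O)c3)ncc21` gives 36300 nM in this assay. Compound 3 stands second highest of the three numbers, but its gap to compound 1 and its gap to compound 2 both fall within the usual scatter, so no firm order among these three can be drawn. Compound 4 `CSc1ccc(/C=N/Nc2ncc3c(n2)n(C2CCCC2)c(=O)c(=O)n3C)cc1` has not yet been measured; it differs from compound 3 by 4-(methylsulfanyl)phenyl in place of 3-hydroxyphenyl on a carbon with a double bond to nitrogen. Among the measured compounds shown here, no measured step makes exactly this change. The closest comparisons are all swaps on the same aromatic ring: a 2.6-fold lower number from compound 1 to compound 2 (0.41 log units; beyond the scatter), a 1.5-fold lower number from compound 1 to compound 3 (0.17 log units; within the scatter) and a 1.8-fold higher number from compound 2 to compound 3 (0.24 log units; within the scatter). Only the first of these crosses the scatter, and even it is modest. A small step, if any, is therefore expected in this assay, and a slightly lower number for compound 4 is expected because a 2.6-fold lower number from compound 1 to compound 2 (0.41 log units; beyond the scatter) ran that way. Compound 4 is estimated at 25000 nM, within 8000 nM to 80000 nM, meaning an expected 1.5-fold lower number from compound 3 to compound 4 (0.16 log units; within the scatter).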

Compound 4, half-maximal inhibitory concentration: 21000 nM
Estimate against measurement, compound 4: 1.2-fold (0.08 log units) above; measured number inside the range.
By their numbers in this assay, from the lowest: compounds 2, 4, 3 and 1 (each within the scatter of the next, the first and the last beyond it).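

Among the compounds shown here, at the carbon with a double bond to nitrogen, 4-(methylsulfanyl)phenyl, the first sulfur-bearing group in this set, cannot be told apart in this assay from 3-hydroxyphenyl (a 1.7-fold lower number from compound 3 to compound 4 (0.24 log units; within the scatter)) or from 3-methoxyphenyl (a 1.0-fold higher number from compound 2 to compound 4 (0.01 log units; within the scatter)). Only the swap from 3-methylphenyl crosses the scatter (a 2.6-fold lower number from compound 1 to compound 4 (0.41 log units; beyond the scatter)), and that step is modest, while compound 3 goes against any clean split of compound 1 from the others (a 1.5-fold lower number from compound 1 to compound 3 (0.17 log units; within the scatter)). Compound 4 changes both the group and its place on the ring, the data do not separate these two changes, and no measurement is available that would explain the steps.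

Going by these compounds, whether 4-methoxyphenyl or 3-(methylsulfanyl)phenyl would read the same remains open. So does the outcome for an amine or a carboxylic acid on this ring.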